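Benzyloxy aryl variation in the acylthiourea series: compound 4

The compounds below may be only part of what the source reports. "The series", "measured", "known", "first", "only" and "open" are said of these compounds alone.

Measured so far in a functional assay on MNK45 cells (Homo sapiens) for inhibition, read by MTT assay, with a stated time of 48 h; on this read-out lower numbers stand for stronger inhibition and higher numbers for weaker inhibition:
compound 1 `Cc1ccc(NC(=S)NC(=O)c2ccc(OCc3ccc(C(F)(F)F)cc3)cc2)cc1-c1nc2ccccc2[nH]1` gives 10200 nM
compound 2 `Cc1ccc(NC(=S)NC(=O)c2ccc(OCc3ccccc3F)cc2)cc1-c1nc2ccccc2[nH]1` gives 2420 nM
compound 3 `Cc1ccc(NC(=S)NC(=O)c2ccc(OCc3ccccc3Cl)cc2)cc1-c1nc2ccccc2[nH]1` gives 51400 nM

Compound 2 stands with the lowest number of the three in this assay; compound 1 is nearest and compound 3 furthest, both beyond the scatter. The two measured steps leading away from compound 2 read a 4.2-fold lower number from compound 1 to compound 2 (0.62 log units; beyond the scatter) and a 21-fold higher number from compound 2 to compound 3 (1.33 log units; beyond the scatter); the third connection is a 5.0-fold higher number from compound 1 to compound 3 (0.70 log units; beyond the scatter).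

Compound 4 `Cc1ccc(NC(=S)NC(=O)c2ccc(OCc3ccc(Cl)cc3Cl)cc2)cc1-c1nc2ccccc2[nH]1` differs from compound 2 by 2,4-dichlorophenyl in place of 2-fluorophenyl on a saturated chain carbon bound to an oxygen on an aromatic ring. Among the measured compounds shown here, the change combines the chloro in place of fluoro already seen between compound 2 and compound 3, which gave a large rise, with a second chloro on the same ring for which no single step exists; the only other ring bearing a group at that position is the 4-(trifluoromethyl)phenyl of compound 1, whose number lies between those of compound 2 and compound 3. The step of a 21-fold higher number from compound 2 to compound 3 (1.33 log units; beyond the scatter) bears most directly, so a higher number beyond the scatter is expected for compound 4 in this assay, though the second chloro leaves its exact size open. The expected step is a 10-fold higher number from compound 2 to compound 4 (1.01 log units; beyond the scatter). Compound 4 is estimated at 25000 nM, within 6000 nM to 100000 nM.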

Compound 4, half-maximal inhibitory concentration: 5300 nM
For compound 4 the middle estimate is 4.7-fold (0.67 log units) above the measured one; measured number below the stated range.
By their numbers in this assay, from the lowest: compound 2; then compounds 4 and 1 (each within the scatter of the next); then compound 3.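

In this assay, adding a further chloro to the ring gives a 9.7-fold lower number from compound 3 to compound 4 (0.99 log units; beyond the scatter), so on this benzyl ring the second chloro runs against the rise that came with the first chloro and largely takes it back. Measured directly, 2,4-dichlorophenyl in place of 2-fluorophenyl gives only a 2.2-fold higher number from compound 2 to compound 4 (0.34 log units; beyond the scatter), which is beyond the scatter but much smaller than a 21-fold higher number from compound 2 to compound 3 (1.33 log units; beyond the scatter), so the step from compound 2 to compound 3 alone is a poor guide to a ring carrying two chloro groups. The position also tolerates two quite different rings without a readable separation, as a 1.9-fold lower number from compound 1 to compound 4 (0.28 log units; within the scatter) shows for the 4-(trifluoromethyl)phenyl and 2,4-dichlorophenyl groups.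

The compounds shown offer no measurement that accounts for the effect of the second chloro. Still open, from the compounds shown here alone, is whether a 4-chlorophenyl ring on its own would sit nearer compound 3 or compound 4, and how a ring bearing an amine or a carboxylic acid would read at this position.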